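The source may hold more compounds than are shown below. What is called first, only, known or untested is meant among the compounds shown, and "the series" means these compounds.

In a functional assay on A549 cells (Homo sapiens) for cytotoxicity, read by MTT assay, with a stated time of 48 h (a lower number here means a stronger inhibitor, a higher number a weaker inhibitor), compound 1 `COc1ccc(-c2c[nH]c(=O)n2-c2cc(OC)c(OC)c(OC)c2)cc1[N+](=O)[O-]` gives > 50000 nM as its reading, which is a limit of the assay and not a number. Among the compounds with values here, compound 2 `COc1cc(-n2c(-c3ccc(Br)cc3)cn(C(C)=O)c2=O)cc(OC)c1OC` gives 1300 nM as the only actual number so far. Compound 3 `COc1cc(-n2c(-c3ccc([N+](=O)[O-])cc3)cn(C(C)=O)c2=O)cc(OC)c1OC` differs from compound 2 in one place, going from 4-bromophenyl to 4-nitrophenyl, and that change nitro in place of bromo on an aromatic carbon leaves the rest untouched. Within the data shown here, no measured pair shows this swap, so only a modest move towards a weaker inhibitor is expected, an estimated 2.3-fold higher number from compound 2 to compound 3 (0.36 log units; beyond the scatter) overall. Compound 3 is estimated at 3000 nM with an expected range from 700 nM to 15000 nM around that figure.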

Compound 3, half-maximal inhibitory concentration: 49600 nM
Estimate against measurement, compound 3: 17-fold (1.22 log units) below; measured number outside the range, above it.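

Swapping 4-bromophenyl for 4-nitrophenyl in this assay gives a 38-fold higher number from compound 2 to compound 3 (1.58 log units; beyond the scatter), so the group at this one aromatic position matters greatly on the core of compound 2. Compound 3 therefore keeps almost none of the activity of compound 2, and its reading lies close to the top of what the assay reports: the limit of > 50000 nM in this assay, at which 1 of the 3 values shown sits.

From the compounds shown here alone, how a chloro group, an amine or a carboxylic acid would read at this position remains open. Two groups alone cannot tell whether bromo is unusually good or nitro unusually poor here.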